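The source may report more compounds than this note shows. Statements on the series, on what has been measured and on what is new or still open speak of the compounds shown alone.

Compound 1, `CCCCCCNc1nc(SC)nc2ncccc12`, is the weakest of the three compounds measured here: in a functional assay (Nicotiana tabacum) (on this read-out lower numbers stand for stronger inhibition and higher numbers for weaker inhibition), compound 1 gives 3330 nM, the highest of the three numbers. Compound 2, `CSc1nc(NC2CCC2)c2cccnc2n1`, gives 720 nM in this assay, and compound 3, `CCC(C)Nc1nc(SC)nc2ncccc12`, gives 860 nM. Replacing the hexyl group with a smaller branched or ring group helped in both cases: a 4.6-fold lower number from compound 1 to compound 2 (0.67 log units; beyond the scatter) and a 3.9-fold lower number from compound 1 to compound 3 (0.59 log units; beyond the scatter). Between the two smaller groups the data show no difference worth the name, as a 1.2-fold higher number from compound 2 to compound 3 (0.08 log units; within the scatter).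

Compound 4, `CSc1nc(Nc2ccccc2)c2cccnc2n1`, differs from compound 1 in one place: phenyl in place of hexyl on a nitrogen on an aromatic ring. The two steps that bear on this change, from hexyl to cyclobutyl and from hexyl to sec-butyl, each lowered the number modestly. The new group is a ring rather than a chain, so the step in this assay is expected to fall in the same direction, though its size is uncertain because no aromatic ring at this nitrogen has been measured. Compound 4 is therefore expected to give 1200 nM, within a range of 350 nM to 4000 nM, which corresponds to an expected step of a 2.8-fold lower number from compound 1 to compound 4 (0.44 log units; beyond the scatter).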

Compound 4, half-maximal inhibitory concentration: 15900 nM
The estimate for compound 4 lay 13-fold (1.12 log units) below the measured number; measured number above the stated range.
By their numbers in this assay, from the lowest: compounds 2 and 3 (each within the scatter of the next); then compound 1; then compound 4.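

Phenyl and hexyl have the same count of heavy atoms, yet in this assay the change from hexyl to phenyl raised the number (a 4.8-fold higher number from compound 1 to compound 4 (0.68 log units; beyond the scatter)), so a ring on this nitrogen does not lower the number in itself. The steps from the two smaller groups are larger (an 18-fold higher number from compound 3 to compound 4 (1.27 log units; beyond the scatter); a 22-fold higher number from compound 2 to compound 4 (1.34 log units; beyond the scatter)), which leaves compound 4 the weakest of the four and shows that this position separates the aromatic phenyl from the non-aromatic cyclobutyl ring. Nothing available here accounts for this reversal.

The compounds shown leave open whether the high number belongs to the aromatic ring or to a six-membered ring of any kind, which a cyclohexyl group would address. Also open, from the compounds shown here alone, is how a benzyl group, or a phenyl ring bearing a methoxy group, would read in this assay.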